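This account rests on a few compounds, and the source may have more. Where it says the series, first, only, none or still open, it means among the compounds named here.

- Compound 1 `CCNc1cc(-c2ccc(NC(=O)Nc3ccc(C)cc3)cc2C)ccn1`: 22000 nM
- Compound 2 `CCNc1cc(-c2ccc(NC(=O)Nc3ccc(C(F)(F)F)cc3)cc2C)ccn1`: 19700 nM

Both values come from a functional assay on BT-483 cells (Homo sapiens) for cytotoxicity, read by MTT assay, with a stated time of 24 h; on this read-out lower numbers stand for stronger inhibition and higher numbers for weaker inhibition. Among the compounds with values here, the only measured step is a 1.1-fold lower number from compound 1 to compound 2 (0.05 log units; within the scatter), with trifluoromethyl in place of methyl on an aromatic carbon. On these numbers, compound 2 therefore cannot be separated from the other measured compound.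

Compound 3 `CCNc1cc(-c2ccc(NC(=O)Nc3c(C)cccc3C)cc2C)ccn1` has not yet been measured. It differs from compound 2 by 2,6-dimethylphenyl in place of 4-(trifluoromethyl)phenyl on an amide-type nitrogen. Within the data shown here, the one measured step bears on this change only in part, since it also altered this aromatic group. Among the measured compounds shown here, no measured compound carries 2,6-dimethylphenyl, so the range must stay wide. For the measured compounds named here, with only that small step as a guide, no shift beyond the scatter is expected in this assay. The estimated step is a 1.1-fold higher number from compound 2 to compound 3 (0.03 log units; within the scatter). Compound 3 is expected at 21000 nM, with an estimated range of 9000 nM to 48000 nM.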

Compound 3, half-maximal inhibitory concentration: > 30000 nM
Compound 3 gave a limit, no number (the forecaster's own chance of this, stated with the estimate: 15%); middle value at least 1.4-fold (0.15 log units) away from the limit.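

In this assay, compound 3 returned a limit and not a number: the limit of > 30000 nM in this assay, at which 1 of the 3 values shown sits.

Replacing the substituted phenyl group on the amide-type nitrogen gives an at least 1.5-fold higher number from compound 2 to compound 3 (0.18 log units; that floor lies within the scatter), and the same kind of change gives an at least 1.3-fold higher number from compound 1 to compound 3 (0.13 log units; that floor lies within the scatter). Unlike the earlier exchange of methyl for trifluoromethyl, this change shows that 2,6-dimethylphenyl at this place brings no lower number, although both floors lie within the scatter and the true size of each step cannot be read.

Going by these compounds, it remains open whether an unsubstituted phenyl, or a phenyl carrying an amine or a carboxylic acid, on this nitrogen would move the number beyond the scatter. The compounds shown also leave open how changes elsewhere on the shared core, such as a longer chain in place of the ethyl group, would read in this assay.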